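This account rests on a few compounds, and the source may have more. Where it says the series, first, only, none or still open, it means among the compounds named here.

Measured so far in a functional assay on SK-MEL-5 cells (Homo sapiens) for inhibition, read by sulforhodamine B assay, with a stated time of 48 h, tested at 1 uM; a lower number here means a stronger effect, a higher number a weaker effect of the compound at the concentration tested:
compound 1 `O=C(Nc1cccc(-n2cc(-c3ccncc3)c(-c3cc(O)cc(Cl)c3)n2)c1)Nc1ccc(Cl)c(Cl)c1`, 86%
compound 2 `COc1cc(Cl)cc(-c2nn(-c3cccc(NC(=O)Nc4ccc(Cl)c(C(F)(F)F)c4)c3)cc2-c2ccncc2)c1`, 83%

In this assay compound 2 gives 83% and compound 1 gives 86%; the two values lie within the scatter of each other, so neither compound stands apart from the other. Compound 3 `COc1cc(Cl)cc(-c2nn(-c3cccc(NC(=O)Nc4cccc(C(F)(F)F)c4)c3)cc2-c2ccncc2)c1` is not yet measured. It differs from compound 2 in one place: hydrogen in place of chloro on an aromatic carbon. For the measured compounds named here, no step between measured compounds covers a change of this kind, so the size cannot be gauged from the series. The step of a number 4 percentage points higher from compound 2 to compound 3 (within the scatter) is expected to be small, not beyond the scatter, in either direction. Compound 3 is expected to give 87%, in the range 72% to 100%.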

Compound 3, a percentage reported as activity, at one concentration (the size of the read-out at that concentration, not a potency): 80%
For compound 3 the middle estimate is 7 percentage points above the measured one; the measured number falls inside the stated range.
By their numbers in this assay, from the lowest: compounds 3, 2 and 1 (each within the scatter of the next).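

Hydrogen in place of chloro on the aromatic carbon ortho to the trifluoromethyl group gives a number 3 percentage points lower from compound 2 to compound 3 (within the scatter) in this assay. For the compounds shown here, this is the first reading at this position: going from 4-chloro-3-(trifluoromethyl)phenyl to 3-(trifluoromethyl)phenyl leaves the read-out at the tested concentration within the scatter, so the chloro group is not required here for that read-out. No measurement shown speaks to the reason for this result.

The compounds shown leave open what an amine or a carboxylic acid on this carbon would give. They also leave open whether the trifluoromethyl group can give way to hydrogen in the same manner.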